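Methoxycarbonyl in place of ethoxycarbonyl on the shared core

The source may hold more compounds than are shown below. What is called first, only, known or untested is meant among the compounds shown, and "the series" means these compounds.

Three compounds of the series carry a measurement in a functional assay on the whole organism for inhibition, with Rattus norvegicus as the target, at a dose of 50 mg/kg by the oral route; a higher number here means more inhibition at the dose given (going by the name of the read-out), a lower number less inhibition. Compound 1 `CCOC(=O)c1c(CSc2nccn2C)nc2cc(OC)c(OC)cc2c1-c1ccc(OC)c(OC)c1` gives 60% in this assay, compound 2 `CCOC(=O)c1c(CSc2ncc[nH]2)nc2cc(OC)c(OC)cc2c1-c1ccc(OC)c(OC)c1` gives 60%, and compound 3 `CCOC(=O)c1c(CSc2nccn2CC)nc2cc(OC)c(OC)cc2c1-c1ccc(OC)c(OC)c1` gives 51%. Compound 1 stands level with compound 2 at the digits shown, the two together the highest of the three numbers, with compound 3 the furthest from it. The step of no change at the digits printed from compound 1 to compound 2 (within the scatter), the step of a number 9 percentage points lower from compound 1 to compound 3 (within the scatter) and the step of a number 9 percentage points lower from compound 2 to compound 3 (within the scatter) all concern the aromatic nitrogen and stay within the scatter.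

Compound 4 `COC(=O)c1c(CSc2nccn2C)nc2cc(OC)c(OC)cc2c1-c1ccc(OC)c(OC)c1` differs from compound 1 by hydrogen in place of methyl on a saturated chain carbon bound to an oxygen next to a carbonyl group. Among the measured compounds shown here, no measured step touches this place, so the only guidance is that every step so far, at a different place, stayed within the scatter. The step of a number 5 percentage points lower from compound 1 to compound 4 (within the scatter) is therefore expected to stay within the scatter, with no direction favoured. Compound 4 is estimated at 55%, with a range from 40% to 70%.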

Compound 4, a percentage reported as inhibition, in the whole organism at one dose (the size of the read-out at that dose, not a potency): 67%
Estimate against measurement, compound 4: 12 percentage points below, and the stated range covers the measured number.
By their numbers in this assay, from the lowest: compounds 3, 1, 2 and 4 (each within the scatter of the next, the first and the last beyond it).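

In this assay, among the compounds shown here, the ester on the shared core is touched for the first time: going from ethoxycarbonyl to methoxycarbonyl, with hydrogen in place of methyl on a saturated chain carbon bound to an oxygen next to a carbonyl group, gives a number 7 percentage points higher from compound 1 to compound 4 (within the scatter) and so sets no direction. For the compounds shown here, this place, like the aromatic nitrogen, therefore shows no step beyond the scatter, although only this one pair speaks for it. No data accompany the result that could explain it.

On these data alone, whether a longer chain such as propyl on that oxygen, a primary amide or the free carboxylic acid in place of the ester would keep the number stays open. So does whether methoxycarbonyl behaves the same way when the aromatic nitrogen carries hydrogen or ethyl instead of methyl.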